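The source may report more compounds than this note shows. Statements on the series, on what has been measured and on what is new or still open speak of the compounds shown alone.

Compound 1 `O=C(O)[C@@H]1CCCN1C(=O)CN(c1nc(Cl)nc2[nH]cnc12)C1CC1`: 23.6%
Compound 2 `C[C@@H](O)[C@H](NC(=O)CN(c1nc(Cl)nc2[nH]cnc12)C1CC1)C(=O)O`: 37.6%
Compound 3 `C[C@H](NC(=O)CN(c1nc(Cl)nc2[nH]cnc12)C1CC1)C(=O)O`: 28.4%

The three measured compounds share one core and differ only in the acid-bearing group on the carbonyl carbon. All were tested in a functional assay on the whole organism (Tail, strain ICR) with Mus musculus as the target, in the tail flick test, with a stated time of 120 min, at a dose of 25 umol/kg by the oral route; a higher number here means a stronger effect of the compound at the dose given, a lower number a weaker effect. Compound 3 stands second of the three numbers shown, but the step of a number 4.8 percentage points higher from compound 1 to compound 3 (within the scatter) and the step of a number 9.2 percentage points lower from compound 2 to compound 3 (within the scatter) both lie within the scatter, so these numbers alone do not separate compound 3 from compound 1 or compound 2. Going by the values given here, only the step of a number 14 percentage points higher from compound 1 to compound 2 (beyond the scatter) is beyond the scatter, and it is modest.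

Compound 4 `O=C(O)CC[C@H](NC(=O)CN(c1nc(Cl)nc2[nH]cnc12)C1CC1)C(=O)O` has not yet been measured in this assay. It differs from compound 3 by carboxymethyl in place of hydrogen on a saturated chain carbon, two bonds along the chain from an amide-type nitrogen and a carbonyl carbon. Among the compounds with values here, no measured step adds a carboxymethyl group on a saturated chain carbon, so none bears directly on this change. The closest comparison is the step of a number 9.2 percentage points lower from compound 2 to compound 3 (within the scatter), which swaps one group on the same chain carbon and stays within the scatter. The change is expected to be small, and a number 1.6 percentage points higher from compound 3 to compound 4 (within the scatter) is the expected step, with no direction beyond the scatter. Compound 4 is expected to give 30%, within a range from 15% to 45%.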

Compound 4, a percentage reported as activity, at one dose (the size of the read-out at that dose, not a potency): 30.1%
Beside the measured number, compound 4's estimate is 0.1 percentage points below it; low and high end bracket the measured number.
By their numbers in this assay, from the lowest: compounds 1, 3, 4 and 2 (each within the scatter of the next, the first and the last beyond it).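

Compound 4 carries a further carboxylic acid on the side chain, and in this assay adding the carboxymethyl group gives a number 1.7 percentage points higher from compound 3 to compound 4 (within the scatter) on going to the longer chain. Going by these compounds alone, this shows that the chain carbon tolerates the 2-carboxyethyl group without a change that can be read at this dose, something the earlier compounds could not show, since their side chains held no second carboxylic acid. Set against the 1-hydroxyethyl group, the same chain gives a number 7.5 percentage points lower from compound 2 to compound 4 (within the scatter), so methyl, 1-hydroxyethyl and 2-carboxyethyl on this carbon cannot be told apart here, and no measurement shown offers a cause for this flat result.

Still open, as far as these compounds go, is how this carbon would respond to a side chain of another kind, such as an amine at the end of a longer chain, a phenyl ring, or a carboxylic acid set one carbon nearer or further out. A reading at a single dose and a single time also leaves open whether the compounds would separate at other doses or at other times.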